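The source may hold more compounds than are shown below. What is called first, only, known or untested is meant among the compounds shown, and "the series" means these compounds.

Measured compounds:
Compound 1 `CCOC(=O)C1=C(C)NC(C)=C(C(=O)OC)C1c1cnc(SC)n1Nc1ccccc1` gives 1.66 nM in an assay on isolated protein (strain albino) for antagonist activity at Voltage-dependent L-type calcium channel subunit alpha-1C (Cavia porcellus); on this read-out lower numbers stand for stronger inhibition and higher numbers for weaker inhibition.
Compound 2 `COC(=O)C1=C(C)NC(C)=C(C(=O)OCCCc2ccccc2)C1c1cnc(SC)n1Nc1ccccc1` gives 3.05 nM in this assay.

For the measured compounds named here, compound 1 shows the lowest of the two numbers, but its only neighbour, compound 2, sits within the scatter of it: a 1.8-fold higher number from compound 1 to compound 2 (0.26 log units; within the scatter). Compound 3 `CCOC(=O)C1=C(C)NC(C)=C(C(=O)OC(C)C)C1c1cnc(SC)n1Nc1ccccc1` has not been measured in this assay. It differs from compound 1 by isopropyl in place of methyl on an oxygen next to a carbonyl group. Going by the values given here, no measured step alters this part of the molecule; the one step available, from compound 1 to compound 2, alters the other ester chain of the shared core and stays within the scatter. On that basis a comparable, small step is expected for the change from methyl to isopropyl, with no confident direction. Compound 3 is therefore estimated at 2 nM in this assay, with a range from 0.8 nM to 5 nM, which amounts to an expected step of a 1.2-fold higher number from compound 1 to compound 3 (0.08 log units; within the scatter).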

Compound 3, half-maximal inhibitory concentration: 3.22 nM
Compound 3: middle estimate off by 1.6-fold (0.21 log units), on the low side; low and high end bracket the measured number.
By their numbers in this assay, from the lowest: compounds 1, 2 and 3 (each within the scatter of the next).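

At this place, on an oxygen next to a carbonyl group, isopropyl in place of methyl gives a 1.9-fold higher number from compound 1 to compound 3 (0.29 log units; within the scatter) in this assay. This gives the position a measured step of its own, and the change from methoxycarbonyl to isopropoxycarbonyl stays within the scatter, as does the change on the other ester chain, a 1.8-fold higher number from compound 1 to compound 2 (0.26 log units; within the scatter), so neither step among these compounds goes beyond it. No supporting data bear on why this step is so small.

With a single step at this place, the compounds shown give no trend for the group on this oxygen. They leave open whether a longer chain, a chain ending in an amine, or a carboxylic acid in place of the methyl ester would also stay within the scatter of compound 1.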